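The compounds below may be only part of what the source reports. "The series", "measured", "known", "first", "only" and "open" are said of these compounds alone.

Among the compounds with values here, in a functional assay on cells (Homo sapiens) for cytotoxicity, read by MTT assay, with a stated time of 48 h (a lower number here means a stronger inhibitor, a higher number a weaker inhibitor), compound 1 (`CN(CC(=O)Nc1cc(O)ccc1O)c1ccccc1`) gives 6000 nM as the lowest number measured so far. Compound 3 (`O=C(CNc1ccccc1)Nc1cc(O)ccc1O`) gives 13000 nM as its number, and hydrogen in place of methyl on the nitrogen makes a 2.2-fold higher number from compound 1 to compound 3 (0.34 log units; beyond the scatter) a modest step. Compound 2 (`CN(CC(=O)Nc1cccc(O)c1)c1ccccc1`) gives > 100000 nM as a limit of the assay, not a number. Removing a hydroxy group produced the large step, an at least 16-fold higher number from compound 1 to compound 2 (1.22 log units; beyond the scatter) in size. Compound 4 (`CN(CC(=O)Nc1cc(O)ccc1O)C1CCCCC1`) keeps that hydroxy group: cyclohexyl in place of phenyl on an amine nitrogen puts cyclohexyl in place of phenyl on an amine nitrogen. Only the modest 2.2-fold higher number from compound 1 to compound 3 (0.34 log units; beyond the scatter) bears on this nitrogen, so a small rise is expected in this assay, perhaps none beyond the scatter. The estimated step is a 2.0-fold higher number from compound 1 to compound 4 (0.30 log units; within the scatter) in size. Compound 4 is expected at 12000 nM within a range from 4000 nM to 40000 nM as its likely span.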

Compound 4, half-maximal inhibitory concentration: 9000 nM
Estimate against measurement, compound 4: 1.3-fold (0.12 log units) above, within the range that was stated.
By their numbers in this assay, from the lowest: compounds 1, 4 and 3 (each within the scatter of the next, the first and the last beyond it). At a limit, above all of these: compound 2.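

In this assay, putting cyclohexyl in place of phenyl on the amine nitrogen gives a 1.5-fold higher number from compound 1 to compound 4 (0.18 log units; within the scatter), so an aromatic ring at this place is not required for activity of this size. Earlier compounds changed only the methyl on this nitrogen or a hydroxy group, whereas this change touches the ring itself. No measurement shown bears on why the two rings give such similar numbers.

On these data alone, whether a longer chain such as hexyl could stand in place of the ring remains open. So does the effect of a carboxylic acid on that ring.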